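This account rests on a few compounds, and the source may have more. Where it says the series, first, only, none or still open, it means among the compounds named here.

Measured compounds:
Compound 1, `Cc1cc(=O)n(-c2ccc(F)cc2)nc1C(=O)Nc1ccc(Oc2ncnc3ccsc23)cc1`: 4400 nM
Compound 2, `Cc1cc(=O)n(-c2ccc(F)c(F)c2)nc1C(=O)Nc1ccc(Oc2ncnc3ccsc23)cc1`: 5550 nM
Compound 3, `Cc1cc(=O)n(-c2ccc(F)c(F)c2)nc1C(=O)Nc1ccc(Oc2ncnc3ccsc23)c(F)c1`: 6900 nM

These three values come from a functional assay on MCF7 cells (Homo sapiens) for cytotoxicity, read by MTT assay, with a stated time of 72 h; on this read-out higher numbers stand for weaker inhibition and lower numbers for stronger inhibition. Compound 2 gives the second highest of the three numbers; its nearest neighbour is compound 3, and its furthest is compound 1, but both gaps are within the scatter, so the three compounds cannot be told apart on this read-out. The two measured steps, a 1.3-fold higher number from compound 1 to compound 2 (0.10 log units; within the scatter) and a 1.2-fold higher number from compound 2 to compound 3 (0.09 log units; within the scatter), each put fluoro in place of hydrogen on an aromatic carbon, and each stayed within the scatter.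

Compound 4, `Cc1cc(=O)n(-c2ccc(F)c(F)c2)nc1C(=O)Nc1ccc(Oc2ncnc3sccc23)cc1`, differs from compound 2 by a group of 9 heavy atoms (6 carbon, 2 nitrogen, 1 sulfur; one five-membered aromatic ring with 1 hetero atom, one six-membered aromatic ring with 2 hetero atoms) in place of a group of 9 heavy atoms (6 carbon, 2 nitrogen, 1 sulfur; one five-membered aromatic ring with 1 hetero atom, one six-membered aromatic ring with 2 hetero atoms), on an oxygen on an aromatic ring; the two have the same atoms, joined differently. Neither measured step touches this part of the molecule, so the data give no direct guide to the size of this change. With no evidence pointing in either direction, the expectation for compound 4 in this assay is a number close to that of compound 2, carrying a wider range than the scatter alone, that is a step of a 1.0-fold lower number from compound 2 to compound 4 (0.00 log units; within the scatter). The estimate for compound 4 is therefore 5500 nM, with a range from 2500 nM to 12000 nM.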

Compound 4, half-maximal inhibitory concentration: 16100 nM
Compound 4: middle estimate off by 2.9-fold (0.47 log units), on the low side, outside the stated range (above it).
By their numbers in this assay, from the lowest: compounds 1, 2 and 3 (each within the scatter of the next); then compound 4.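

In this assay, rejoining the same atoms of the group on the oxygen gives a 2.9-fold higher number from compound 2 to compound 4 (0.46 log units; beyond the scatter), a modest step and the only one in this series beyond the scatter. The group that leaves and the group that enters have the same heavy atoms, the same two aromatic rings, the same counts of hydrogen-bond donors and acceptors and no net charge, so none of these counts separates them and the difference lies only in how the atoms are joined. The earlier fluoro steps, both within the scatter, gave no sign that this read-out could move at all, whereas this change shows that it responds to the arrangement of the group at this position, though no measurement shown accounts for the step.

As far as these compounds go, whether the step is the same size on the backgrounds of compound 1 and compound 3 remains open. Also open, from the compounds shown here alone, is how this assay would respond to a methyl group, a chloro group or an amine added to the group that enters.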